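From 2-Methoxyphenyl to 3-Bromophenyl on the Amide

The compounds below may be only part of what the source reports. "The series", "measured", "known", "first", "only" and "open" are said of these compounds alone.

In a functional assay on HepG2 cells (Homo sapiens) for inhibition, read by MTT assay, with a stated time of 72 h (a higher number here means a weaker inhibitor, a lower number a stronger inhibitor), compound 1 (`CC(C)c1ccc(NC(=O)C2CCN(C/C=C/c3ccccc3)CC2)cc1`) gives 12200 nM while compound 2 (`COc1ccccc1NC(=O)C1CCN(C/C=C/c2ccccc2)CC1`) gives 91200 nM as the higher of the two numbers. Going by the values given here, the only measured step is a 7.5-fold higher number from compound 1 to compound 2 (0.87 log units; beyond the scatter) and it bears on the next change only indirectly, since it too concerns the 2-methoxyphenyl group at this place. Compound 3 (`O=C(Nc1cccc(Br)c1)C1CCN(C/C=C/c2ccccc2)CC1`) carries 3-bromophenyl in place of 2-methoxyphenyl on an amide-type nitrogen. Among the compounds with values here, no measured compound holds the 3-bromophenyl group, and the data give no direct reading of it. Within the data shown here, the one compound without 2-methoxyphenyl, compound 1 at 12200 nM in this assay, points to an expected move toward a lower number, probably smaller than the measured step. The expected change is a 2.6-fold lower number from compound 2 to compound 3 (0.42 log units; beyond the scatter) as estimated here. The estimate for compound 3 is 35000 nM within an expected range (12000 nM to 90000 nM).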

Compound 3, half-maximal inhibitory concentration: 19200 nM
Compound 3: middle estimate off by 1.8-fold (0.26 log units), on the high side; the measured number falls inside the stated range.
By their numbers in this assay, from the lowest: compounds 1 and 3 (each within the scatter of the next); then compound 2.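

In this assay, 3-bromophenyl in place of 2-methoxyphenyl on an amide-type nitrogen gives a 4.8-fold lower number from compound 2 to compound 3 (0.68 log units; beyond the scatter) and so shows that a second group at this place stands clear of 2-methoxyphenyl, not only 4-isopropylphenyl. The comparison with the other group gives a 1.6-fold higher number from compound 1 to compound 3 (0.20 log units; within the scatter) and lies within the scatter, so 3-bromophenyl and 4-isopropylphenyl cannot be told apart here, and compound 2 is the one that stands apart among the three. No measurement at hand gives a reason for these steps.

The compounds shown leave open whether the gap belongs to the methoxy group itself or to where it sits, a question that 3-methoxyphenyl or 2-bromophenyl would address. As far as these compounds go, how an amine or a carboxylic acid on the phenyl ring would behave at this place also remains open.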